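Substituent swap at the aromatic carbon of the shared core

A few compounds are considered here, and "the series" means these few. Any claim that something is new, unique, unknown or untested is made for them only; others in the source may bear on it.

Measured so far in an assay on T-REx-293 cells for inhibition of potassium channel subfamily T member 1 (Homo sapiens), read by patch clamp; a higher number here means a weaker inhibitor, a lower number a stronger inhibitor:
compound 1 `C[C@H](NC(=O)c1cc(C(F)(F)F)nn1C)c1nc(-c2ccncc2)no1`: 5250 nM
compound 2 `C[C@H](NC(=O)c1cc(C(F)(F)F)nn1C)c1nc(-c2ccnc(N3CCCC3)c2)no1`: 573 nM

Compound 2 holds the lower of the two numbers in this assay; the step of a 9.2-fold lower number from compound 1 to compound 2 (0.96 log units; beyond the scatter) lies beyond the scatter. Compound 3 `CO[C@H](C)c1cc(-c2noc([C@H](C)NC(=O)c3cc(C(F)(F)F)nn3C)n2)ccn1` differs from compound 2 by 1-methoxyethyl in place of pyrrolidin-1-yl on an aromatic carbon. Among the measured compounds shown here, the only step that bears on this change is a 9.2-fold lower number from compound 1 to compound 2 (0.96 log units; beyond the scatter), which shows that placing a group on this carbon lowers the number. From the compounds shown here alone, whether 1-methoxyethyl retains the whole of that gain is unknown, so a partial loss is expected. Compound 3 is estimated at 1500 nM, between 500 nM and 5000 nM. This expected step is a 2.6-fold higher number from compound 2 to compound 3 (0.42 log units; beyond the scatter).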

Compound 3, half-maximal inhibitory concentration: 778 nM
For compound 3 the middle estimate is 1.9-fold (0.29 log units) above the measured one; the measured number falls inside the stated range.
By their numbers in this assay, from the lowest: compounds 2 and 3 (each within the scatter of the next); then compound 1.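

In this assay a gain at this aromatic carbon appears with an open-chain group as well as with pyrrolidin-1-yl, since 1-methoxyethyl in place of hydrogen gives a 6.7-fold lower number from compound 1 to compound 3 (0.83 log units; beyond the scatter) and so lies beyond the scatter. Exchanging the ring for the chain gives a 1.4-fold higher number from compound 2 to compound 3 (0.13 log units; within the scatter) and so stays within the scatter, which leaves compound 2 and compound 3 level in this assay. No measurement at hand explains this result. From the compounds shown here alone, whether a methoxy group or a primary amine on this carbon would keep the gain remains open, as does the effect of the opposite configuration at the stereocentre of 1-methoxyethyl.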